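Swapping Chloro for Amino on a Shared Fused Core

The source may hold more compounds than are shown below. What is called first, only, known or untested is meant among the compounds shown, and "the series" means these compounds.

Of the compounds shown here, three have so far been measured in a functional assay on NCI-H23 cells (Homo sapiens) for cytotoxicity, read by sulforhodamine B assay, with a stated time of 48 h; a lower number here means a stronger inhibitor of growth, a higher number a weaker inhibitor of growth. Compound 3 `ClCc1ccc(Cn2cnc3c(Cl)nc(Cl)nc32)cc1` gives 23400 nM, and compound 1 `Nc1nc(Cl)c2ncn(Cc3ccc(CCl)cc3)c2n1` gives 30200 nM. These two differ by a single change, (amino in place of chloro on an aromatic carbon), and the step it made was a 1.3-fold higher number from compound 3 to compound 1 (0.11 log units; within the scatter). Compound 2 `ClCc1cccc(Cn2cnc3c(Cl)nc(Cl)nc32)c1` gives 5120 nM in this assay, the lowest of the three numbers; its gaps to compound 3 and to compound 1 both lie beyond the scatter, so among the measured compounds it is the strongest inhibitor of growth. Compound 2 and compound 3 are built from the same atoms joined differently; the difference between the two cores is not broken down here.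

Compound 4 `Nc1nc(Cl)c2ncn(Cc3cccc(CCl)c3)c2n1` has not yet been measured. It stands to compound 2 as compound 1 stands to compound 3: the change is amino in place of chloro on an aromatic carbon, the same change as before, at a place described in exactly the same words. Going by the values given here, the only guide to its size is the earlier pair, where the step was a 1.3-fold higher number from compound 3 to compound 1 (0.11 log units; within the scatter), a step within the scatter. In this assay the expected step is therefore a 1.3-fold higher number from compound 2 to compound 4 (0.11 log units; within the scatter), resting on that single precedent. Among the compounds with values here, for compound 4 the number expected in this assay is 6600 nM, with a range from 2500 nM to 18000 nM that allows for there being only one prior instance of this change.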

Compound 4, concentration for total growth inhibition: 5010 nM
Estimate against measurement, compound 4: 1.3-fold (0.12 log units) above; measured number inside the range.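

In this assay the amino group in place of chloro on the core of compound 2 gave a 1.0-fold lower number from compound 2 to compound 4 (0.01 log units; within the scatter) and so, as on the other core, the change left the number within the scatter. Set side by side, the two steps do not differ beyond what repeated measurement allows: the same change on two cores in this assay, a 1.3-fold higher number (0.11 log units; within the scatter) from compound 3 to compound 1 and a 1.0-fold lower number (0.01 log units; within the scatter) from compound 2 to compound 4, 1.3-fold (0.12 log units) apart, within the scatter of two such steps. Across these two cores, then, the change carried over with no step of measurable size, but this rests on two pairs alone, with the change at the same place in both, between two ring nitrogen atoms, and it does not show that the same would hold on a core of another kind, nor that a step of real size would transfer in this way, nor why the amino and chloro compounds read alike.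

The compounds shown leave open whether a different group at this place, such as a methylamino group, a methoxy group or a hydroxyl group, would also leave the number where it stands. They also leave open what an amine or a thiol would do in place of the chloro group that remains on the same ring in all four compounds.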